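Amino Substitution on a Fused Core: Predicting Compound 4

A few compounds are considered here, and "the series" means these few. Any claim that something is new, unique, unknown or untested is made for them only; others in the source may bear on it.

Measured compounds:
- Compound 1, `Nc1cccn2cc(Cc3ccc(F)cc3)c(=O)nc12`: 126000 nM
- Compound 2, `O=c1nc2ccc(Br)cn2cc1Cc1ccccc1`: 137000 nM
- Compound 3, `O=c1nc2ccccn2cc1Cc1ccc(F)cc1`: 125000 nM

All three were tested in a functional assay on SK-N-SH cells (Homo sapiens) for cytotoxicity, read by MTT assay, with a stated time of 24 h; on this read-out higher numbers stand for weaker inhibition and lower numbers for stronger inhibition. Compound 3 gives 125000 nM. Where compound 3 has a hydrogen, an amino group sits in compound 1, and compound 1 gives 126000 nM. That change is amino in place of hydrogen on an aromatic carbon, and the step it made, a 1.0-fold higher number from compound 3 to compound 1 (0.00 log units; within the scatter), shows that the numbers hardly moved. Compound 2 gives 137000 nM, which sits within the scatter of both other values. How the core of compound 2 differs from that of compound 3 is not broken down here.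

Compound 4, `Nc1cc(Br)cn2cc(Cc3ccccc3)c(=O)nc12`, has not yet been measured. It arises from compound 2 by amino in place of hydrogen on an aromatic carbon. This is the same kind of change as from compound 3 to compound 1, though here the place is also meta to a bromo group (1 heavy atom). Because the earlier step was a 1.0-fold higher number from compound 3 to compound 1 (0.00 log units; within the scatter), the step from compound 2 to compound 4 is expected to be no change at the digits printed from compound 2 to compound 4 (within the scatter) in this assay. Compound 4 is therefore estimated at 137000 nM, within 70000 nM to 270000 nM.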

Compound 4, half-maximal inhibitory concentration: 149000 nM
The estimate for compound 4 lay 1.1-fold (0.04 log units) below the measured number; the measured number falls inside the stated range.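

In this assay, placing an amino group where a hydrogen stood on an aromatic carbon gives a 1.1-fold higher number from compound 2 to compound 4 (0.04 log units; within the scatter), so on this second core, as on the first, the change has no effect that can be told from ordinary assay variation. Setting the two steps side by side shows that the change behaved alike on both cores: the same change on two cores in this assay, a 1.0-fold higher number (0.00 log units; within the scatter) from compound 3 to compound 1 and a 1.1-fold higher number (0.04 log units; within the scatter) from compound 2 to compound 4, 1.1-fold (0.03 log units) apart, within the scatter of two such steps

This supports carrying the change between these two cores in this assay, but it does not show that the same would hold on any other core or in any other test, and it gives no reason why the amino group makes so little difference here.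

The compounds shown carry only hydrogen or amino at this place, so it remains open what a hydroxyl group, a methoxy group or a carboxylic acid would do there. On these data alone, it also remains open whether a longer chain ending in an amine, set at the same place, would move the number beyond the scatter.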